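This account rests on a few compounds, and the source may have more. Where it says the series, first, only, none or still open, it means among the compounds named here.

Measured compounds:
- compound 1, `Cc1cccc(/C(N)=N/NC(=S)N2CCN(c3ccccn3)CC2)n1`: 74.8%
- compound 2, `N/C(=N\NC(=S)N1CCOCC1)c1ccccn1`: 15%
- compound 3, `Cc1cccc(/C(N)=N/NC(=S)N2CCSCC2)n1`: 73.1%

All three numbers come from a functional assay on A-375 cells (Homo sapiens) for cytotoxicity, read by MTT assay, with a stated time of 72 h, tested at 30 uM; on this read-out higher numbers stand for more inhibition of growth at the one concentration tested and lower numbers for less inhibition of growth. Compound 1 stands at the top of the three; the number for compound 3 sits within the usual scatter of it, so the two are not separated by this read-out. Compound 2 sits far lower, a gap beyond the scatter, but compound 2 differs from compound 1 in more than one place, so its number says nothing on its own about any single change.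

Compound 4, `Cc1ccnc(/C(N)=N/NC(=S)N2CCN(c3ccccn3)CC2)c1`, has not been measured in this assay. It differs from compound 1 in one place: 4-methylpyridin-2-yl in place of 6-methylpyridin-2-yl on a carbon with a double bond to nitrogen. The two share every atom and differ only in how they are joined. Going by the values given here, no measured pair isolates this move of the methyl group on the pyridin-2-yl, so there is no step to lean on. Among the compounds with values here, with no such step, the working expectation is that the change produces no movement beyond the scatter of this assay, in either direction.

Compound 4 is therefore estimated at 65%, with a range from 40% to 85%. The step this estimate implies is a number 9.8 percentage points lower from compound 1 to compound 4 (within the scatter), which is expected to stay within the scatter.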

Compound 4, percent growth inhibition at one concentration: 79.4%
For compound 4 the middle estimate is 14.4 percentage points below the measured one; low and high end bracket the measured number.
By their numbers in this assay, from the lowest: compound 2; then compounds 3, 1 and 4 (each within the scatter of the next).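

In this assay, moving the methyl group on the pyridin-2-yl gives a number 4.6 percentage points higher from compound 1 to compound 4 (within the scatter), so 6-methylpyridin-2-yl and 4-methylpyridin-2-yl, on a carbon with a double bond to nitrogen, are not told apart by this read-out. Going by these compounds alone, this is the first pair that isolates a single change, and it shows that growth inhibition at the one concentration tested holds up when the methyl group is moved and the rest of compound 1 stays the same. Nothing available bears on why the two compounds read alike.

The compounds shown leave open what the plain pyridin-2-yl, or an ethyl group, a methoxy group or a chlorine atom in place of the methyl, would give on the core of compound 1, and so whether this ring tolerates change generally or only this one move. Also open, on these data alone, is whether the two compounds would stay together across a range of concentrations, as a single concentration gives no full dose-response curve.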